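The compounds below may be only part of what the source reports. "The series", "measured", "known", "first", "only" and "open" are said of these compounds alone.

Measured compounds:
compound 1 `C[Se]/C(=N\C(=O)c1cc2ccccc2s1)NC(=O)c1cc2ccccc2s1` gives 32700 nM
compound 2 `CS/C(=N\C(=O)c1cccs1)NC(=O)c1cccs1` gives 89000 nM
compound 3 `O=C(/N=C(/NC(=O)c1csc([N+](=O)[O-])c1)[Se]Cc1ccccc1)c1csc([N+](=O)[O-])c1` gives 54100 nM

The account follows compound 1 into an untested neighbour. In a functional assay on MCF7 cells (Homo sapiens) for cytotoxicity, read by MTT assay, with a stated time of 72 h (on this read-out higher numbers stand for weaker inhibition of growth and lower numbers for stronger inhibition of growth), compound 1 gives 32700 nM, the lowest of the three numbers. The gap between compound 1 and compound 3 lies within the usual scatter of this assay, so nothing separates them with confidence; the gap between compound 1 and compound 2, which gives 89000 nM, lies beyond it. For the measured compounds named here, no pair among the three differs in one place only, so no single step can be read off.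

Compound 4 `O=C(/N=C(/NC(=O)c1cc2ccccc2s1)[Se]Cc1ccccc1)c1cc2ccccc2s1` differs from compound 1 by phenyl in place of hydrogen on a saturated chain carbon bound to a selenium atom, which cut one bond further out reads methyl to benzyl. Going by the values given here, compound 3 carries the same benzyl on its selenium atom and gives 54100 nM, but its core differs from that of compound 1, so it offers no clean precedent. Without a measured step of this kind, no shift beyond the scatter is expected in either direction. The step from compound 1 to compound 4 is estimated as a 1.1-fold lower number from compound 1 to compound 4 (0.04 log units; within the scatter), meaning little change. Compound 4 is expected to give 30000 nM, within a range from 10000 nM to 90000 nM.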

Compound 4, concentration for total growth inhibition: 62900 nM
Beside the measured number, compound 4's estimate is 2.1-fold (0.32 log units) below it, and the stated range covers the measured number.
By their numbers in this assay, from the lowest: compounds 1, 3, 4 and 2 (each within the scatter of the next, the first and the last beyond it).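

In this assay, the set now holds its first step between compounds that differ in one place, phenyl in place of hydrogen on a saturated chain carbon bound to a selenium atom, and it reads a 1.9-fold higher number from compound 1 to compound 4 (0.28 log units; within the scatter), a step that lies within the usual scatter. At this position, then, the assay does not separate methyl from benzyl, and the added six-membered aromatic ring of carbon only brings no shift that can be told apart from repeat measurements. No other measurement shown here bears on this result, and no explanation for it can be offered.

The compounds shown leave open whether a different kind of group on the selenium atom, such as a longer straight alkyl chain or a chain ending in an amine or a carboxylic acid, would move the number beyond the scatter. They also leave open whether the same change from methyl to benzyl would read alike on another core, as this single step comes from one core only.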